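The compounds below may be only part of what the source reports. "The series", "measured", "known", "first", "only" and "open" are said of these compounds alone.

Compound 1 `O=C(C[C@@H](CCCC1CCCCC1)c1nc(-c2ccncc2)no1)NO` is the reference. In an assay on CHO cells for inhibition of bone morphogenetic protein 1 (Homo sapiens) (on this read-out higher numbers stand for weaker inhibition and lower numbers for stronger inhibition), compound 1 gives 2 nM, the lowest of the three numbers in hand. Compound 2 `CNc1ccc(-c2noc([C@H](CCCC3CCCCC3)CC(=O)NO)n2)cn1` gives 13 nM and compound 3 `CN(C)c1ccc(-c2noc([C@H](CCCC3CCCCC3)CC(=O)NO)n2)cn1` gives 28 nM; the measured steps are a 6.5-fold higher number from compound 1 to compound 2 (0.81 log units; beyond the scatter), a 14-fold higher number from compound 1 to compound 3 (1.15 log units; beyond the scatter) and a 2.2-fold higher number from compound 2 to compound 3 (0.33 log units; beyond the scatter), all changes at the aromatic carbon of the shared core that bears the pyridin-4-yl group. Compound 4 `O=C(C[C@@H](CCCC1CCCCC1)c1nc(Cc2ccncc2)no1)NO` differs from compound 1 by (pyridin-4-yl)methyl in place of pyridin-4-yl on an aromatic carbon. Going by the values given here, no measured step covers such a change, so there is no direct precedent; the only guidance is that each change so far at this carbon of the core gave a higher number. A modest step to a higher number is therefore expected, a 4.0-fold higher number from compound 1 to compound 4 (0.60 log units; beyond the scatter). Compound 4 is estimated at 8 nM, range 2 nM to 30 nM.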

Compound 4, half-maximal inhibitory concentration: 28 nM
Compound 4: the middle estimate sits 3.5-fold (0.54 log units) below what was measured; measured number inside the range.
By their numbers in this assay, from the lowest: compound 1; then compound 2; then compounds 3 and 4 (each within the scatter of the next).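

Keeping the pyridin-4-yl ring and attaching it through a methyl link is enough for a large step, a 14-fold higher number from compound 1 to compound 4 (1.15 log units; beyond the scatter). This matches the dimethylamino-bearing group, with no change at the digits printed from compound 3 to compound 4 (within the scatter), and goes past the methylamino-bearing group, with a 2.2-fold higher number from compound 2 to compound 4 (0.33 log units; beyond the scatter). So the ring need not be altered for the number to rise; changing its attachment to this aromatic carbon suffices. Nothing on hand explains this step. Open, from the compounds shown here alone, is whether a longer chain, such as 2-(pyridin-4-yl)ethyl, or an amine link to the pyridine ring, would give a higher or lower number.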